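Swapping a Fluoropyrimidine for a Cyanopyridine on a Chlorobenzamide

A few compounds are considered here, and "the series" means these few. Any claim that something is new, unique, unknown or untested is made for them only; others in the source may bear on it.

Of the compounds shown here, three sharing the same core have been tested in a functional assay on HEK293 cells for antagonist activity at P2X purinoceptor 7 (Homo sapiens); a lower number here means a stronger inhibitor, a higher number a weaker inhibitor. Compound 1 `Cc1cnc(-c2ccc(Cl)c(C(=O)NCC3(O)CCCCCC3)c2)nc1` gives 8 nM. Compound 3 `O=C(NCC1(O)CCCCCC1)c1cc(-c2ncc(F)cn2)ccc1Cl` gives 16 nM, and compound 2 `COc1ccc(-c2ccc(Cl)c(C(=O)NCC3(O)CCCCCC3)c2)nc1` gives 213 nM. Compound 3 therefore stands second highest of the three numbers: its nearest neighbour is compound 1, a step of a 2.0-fold higher number from compound 1 to compound 3 (0.30 log units; within the scatter), and its furthest is compound 2, separated by a 13-fold lower number from compound 2 to compound 3 (1.12 log units; beyond the scatter).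

Compound 4 `N#Cc1ccc(-c2ccc(Cl)c(C(=O)NCC3(O)CCCCCC3)c2)nc1` is the next candidate. It differs from compound 3 in one place: 5-cyanopyridin-2-yl in place of 5-fluoropyrimidin-2-yl on an aromatic carbon. Among the measured compounds shown here, two measured steps bear on this. The move from a pyrimidine to a pyridine, together with a change of the small group on it, gave a 27-fold higher number from compound 1 to compound 2 (1.43 log units; beyond the scatter), while changing only the small group on the pyrimidine gave a 2.0-fold higher number from compound 1 to compound 3 (0.30 log units; within the scatter). The new change also mixes a ring switch with a different small group, and a cyano group has not yet been tried here, so the outcome is uncertain. A weakening is expected in this assay, estimated at a 3.8-fold higher number from compound 3 to compound 4 (0.57 log units; beyond the scatter), smaller than that seen with compound 2 but beyond the scatter. Compound 4 is thus expected to give about 60 nM, within a range from 15 nM to 250 nM.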

Compound 4, half-maximal inhibitory concentration: 134 nM
The estimate for compound 4 lay 2.2-fold (0.35 log units) below the measured number, and the stated range covers the measured number.
By their numbers in this assay, from the lowest: compounds 1 and 3 (each within the scatter of the next); then compounds 4 and 2 (each within the scatter of the next).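

Compound 4 sits with the other pyridine, with cyano in place of methoxy giving a 1.6-fold lower number from compound 2 to compound 4 (0.20 log units; within the scatter) in this assay, so these two small groups on the pyridine ring read alike, as the methyl and fluoro groups did on the pyrimidine ring. Among the compounds shown here, the ring change, by contrast, stays beyond the scatter with new pairs of small groups, giving an 8.4-fold higher number from compound 3 to compound 4 (0.92 log units; beyond the scatter) and a 17-fold higher number from compound 1 to compound 4 (1.22 log units; beyond the scatter) in steps that, with the two earlier ones, make four ring-changing steps that all put the pyridine at the higher number, and no compound here goes against this. At this position, the number of hetero atoms in the ring thus tracks the potency better than the small group on the ring does, but no data are available to explain why.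

Every pyridine here carries a different small group from every pyrimidine, so the ring's share of these steps cannot be separated from the small group's share. A 5-methylpyridin-2-yl group set against compound 1 would isolate the ring change, while an amine on either ring would test whether the small group stays this unimportant.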